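Ring stereoisomers of a hydroxylated piperidine acid: inhibition

The compounds below may be only part of what the source reports. "The series", "measured", "known", "first", "only" and "open" are said of these compounds alone.

Measured so far:
compound 1 `O=C(O)[C@H]1NC[C@H](O)[C@H](O)[C@@H]1O`: 4.5%
compound 2 `O=C(O)[C@H]1NC[C@H](O)[C@@H](O)[C@@H]1O`: 0.2%
compound 3 `O=C(O)[C@H]1NC[C@@H](O)[C@@H](O)[C@@H]1O`: 3.8%

In an assay for inhibition of alpha-N-acetylgalactosaminidase (Gallus gallus), tested at 1000 uM (a higher number here means more inhibition at the concentration tested (going by the name of the read-out), a lower number less inhibition), compound 1 gives the largest of the three read-outs, but the steps of a number 4.3 percentage points lower from compound 1 to compound 2 (within the scatter) and a number 0.7 percentage points lower from compound 1 to compound 3 (within the scatter) are both within the scatter, as is a number 3.6 percentage points higher from compound 2 to compound 3 (within the scatter), so the three compounds are not separated by this assay.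

Compound 4 `O=C(O)[C@H]1NC[C@@H](O)[C@H](O)[C@@H]1O` differs from compound 1 in one stereocentre: the two compounds have the same atoms and bonds and differ only in configuration as drawn: 1 of 4 stereo elements differ; a stereocentre at a saturated ring carbon is drawn S in compound 1 and R in compound 4. Each measured step is likewise a change of configuration only the fact that compounds 1 and 2 differ only in the configuration as drawn the fact that compounds 1 and 3 differ only in the configuration as drawn (the fact that compounds 2 and 3 differ only in the configuration as drawn), and none of them moved the read-out beyond the scatter. The step to compound 4 is therefore expected to be of the same kind, a number 1.5 percentage points lower from compound 1 to compound 4 (within the scatter), with no change beyond the scatter. Compound 4 is estimated at 3%, in the range -5% to 12%.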

Compound 4, a percentage reported as inhibition, at one concentration (the size of the read-out at that concentration, not a potency): 11%
Estimate against measurement, compound 4: 8 percentage points below, and the stated range covers the measured number.
By their numbers in this assay, from the lowest: compounds 2, 3, 1 and 4 (each within the scatter of the next, the first and the last beyond it).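

In this assay, the single-centre changes give a number 6.5 percentage points higher from compound 1 to compound 4 (within the scatter) and a number 7.2 percentage points higher from compound 3 to compound 4 (within the scatter), so neither inversion alone separates the compounds. Among the compounds shown here, the only step beyond the scatter so far is a number 10.8 percentage points higher from compound 2 to compound 4 (beyond the scatter), and it spans two stereocentres, so it cannot be assigned to either centre alone. No atoms or bonds change along this step, only configuration: the fact that compounds 2 and 4 differ only in the configuration as drawn

All four compounds carry the same groups. On these data alone, whether a primary amide or a hydroxymethyl group in place of the carboxylic acid would shift the read-out remains open.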